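Swapping the amine side chain back toward a methoxyphenyl group

This account rests on a few compounds, and the source may have more. Where it says the series, first, only, none or still open, it means among the compounds named here.

Of the compounds shown here, three sharing one core have been tested in a functional assay on isolated protein for antagonist activity at Orexin receptor type 2 (Homo sapiens), read by fluorescence, FLIPR and calcium flux, with a stated time of 1 h; a lower number here means a stronger inhibitor, a higher number a weaker inhibitor. Compound 1 `COc1cccc(C(C)NC(=O)COc2cc(C(F)(F)F)c3c(-c4ccccc4)nn(C)c3n2)c1` gives 26 nM. Compound 2 `CC(NC(=O)COc1cc(C(F)(F)F)c2c(-c3ccccc3)nn(C)c2n1)c1ccccn1` is reported as "not active" (no number reported). Compound 3 `CC(NC(=O)COc1cc(C(F)(F)F)c2c(-c3ccccc3)nn(C)c2n1)c1cccnc1` gives 582 nM, the highest of the two numbers, and its nearest neighbour is compound 1 at a much lower number. Going by the values given here, the one measured step bearing on the change is a 22-fold higher number from compound 1 to compound 3 (1.35 log units; beyond the scatter), a large weakening when the pyridin-3-yl replaced the 3-methoxyphenyl.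

Compound 4 `COc1ccc(CNC(=O)COc2cc(C(F)(F)F)c3c(-c4ccccc4)nn(C)c3n2)cc1` differs from compound 3 by 4-methoxybenzyl in place of 1-(pyridin-3-yl)ethyl on an amide-type nitrogen. Among the compounds with values here, this moves in the opposite direction to that step, replacing the pyridine by a methoxyphenyl ring again, although the group is 4-methoxybenzyl rather than the 1-(3-methoxyphenyl)ethyl of compound 1, and no measured pair covers that remaining difference. A return toward a lower number is therefore expected, but with less certainty than a plain reversal would give; the expected step is a 7.3-fold lower number from compound 3 to compound 4 (0.86 log units; beyond the scatter). For compound 4 the estimate in this assay is 80 nM, within a range of 20 nM to 400 nM.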

Compound 4, inhibition constant: 83 nM
Beside the measured number, compound 4's estimate is 1.0-fold (0.02 log units) below it, and the stated range covers the measured number.
By their numbers in this assay, from the lowest: compound 1; then compound 4; then compound 3.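

In this assay, replacing 1-(pyridin-3-yl)ethyl with 4-methoxybenzyl on the amide-type nitrogen gives a 7.0-fold lower number from compound 3 to compound 4 (0.85 log units; beyond the scatter). A methoxyphenyl ring therefore recovers much of the lost inhibition, even without the exact group of compound 1. The recovery is only partial, since 4-methoxybenzyl in place of 1-(3-methoxyphenyl)ethyl still gives a 3.2-fold higher number from compound 1 to compound 4 (0.50 log units; beyond the scatter), so the group of compound 1 remains the better of the two at this nitrogen. No supporting data are available to explain these shifts.

The step between these two groups combines a moved methoxy group with the loss of the chain methyl, so the share of each cannot be separated. A 3-methoxybenzyl or 1-(4-methoxyphenyl)ethyl group would be needed to tell these two changes apart.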